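Trifluoromethyl in place of 4-acetylpiperazin-1-yl

The source may report more compounds than this note shows. Statements on the series, on what has been measured and on what is new or still open speak of the compounds shown alone.

- compound 1 `CC(=O)N1CCN(c2ccc(Nc3ncc(C(F)(F)F)c(N4Cc5cccc(N(C)S(C)(=O)=O)c5C4)n3)cc2)CC1`: 22100 nM
- compound 2 `Cc1ccc(Nc2ncc(C(F)(F)F)c(N3Cc4cccc(N(C)S(C)(=O)=O)c4C3)n2)c(Cl)c1`: > 30000 nM (a limit of the assay, not a number)

For the measured compounds named here, in a functional assay on U-87MG ATCC cells for antiproliferative activity against U-87 MG (Homo sapiens), read by spectrophotometry, with a stated time of 2 days (a lower number here means a stronger inhibitor of growth, a higher number a weaker inhibitor of growth), compound 1 gives 22100 nM, the only actual number among the measured compounds. Compound 2 gives > 30000 nM in this assay, and this value is a limit, not a number. Compound 1 is therefore the single firm reference point.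

Compound 3 `CN(c1cccc2c1CN(c1nc(Nc3ccc(C(F)(F)F)cc3)ncc1C(F)(F)F)C2)S(C)(=O)=O` has not yet been measured. It keeps the core of compound 1 but carries trifluoromethyl in place of 4-acetylpiperazin-1-yl on an aromatic carbon, para to a large group: trifluoromethyl in place of 4-acetylpiperazin-1-yl on an aromatic carbon. Going by the values given here, no step between measured compounds shows what such a change does, so the expectation is a loose one, anchored on compound 1 at 22100 nM. No step beyond the usual scatter is expected, with any drift more likely toward weaker growth inhibition. The estimate amounts to a 1.1-fold higher number from compound 1 to compound 3 (0.05 log units; within the scatter). For compound 3 the expected value is 25000 nM, with an estimated range from 10000 nM to 30000 nM.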

Compound 3, concentration for 50% growth inhibition: > 30000 nM
Compound 3 was reported as a limit (the forecaster's own chance of this, stated with the estimate: 50%); middle value at least 1.2-fold (0.07 log units) away from the limit.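

For the compounds shown here, this is the first measured step at this position. In this assay, putting trifluoromethyl in place of 4-acetylpiperazin-1-yl on an aromatic carbon, para to a large group, gives an at least 1.3-fold higher number from compound 1 to compound 3 (0.13 log units; that floor lies within the scatter). The change brings no measurable gain in growth inhibition, although that floor alone does not prove a real loss, and the true size of the step could be larger. Compound 3 is reported only as a limit, not a number, so neither its step from compound 2 nor any ranking of those two compounds can be read, and the comparison stops at the same limit for both: the limit of > 30000 nM in this assay, at which 2 of the 3 values shown sit.

The compounds shown leave open whether the weak activity of compound 1 depends on the six-membered ring of 4-acetylpiperazin-1-yl, on its acetyl group, or on neither. A piperazin-1-yl group with a free amine, a morpholin-4-yl group or a carboxylic acid at this same place would help separate these possibilities, provided its value fell within the readable range of the assay.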